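Swapping the Phenylpiperazine for a Cyclopentylsulfanyl Group

The compounds below may be only part of what the source reports. "The series", "measured", "known", "first", "only" and "open" are said of these compounds alone.

Compound 1 `CC(C(=O)NCc1ccc(C(F)(F)F)cc1N1CCN(c2ccccc2)CC1)c1ccc(NS(C)(=O)=O)c(F)c1` is the reference point here. In an assay on CHO cells for antagonist activity at transient receptor potential cation channel subfamily V member 1 (Homo sapiens), read by FLIPR (on this read-out lower numbers stand for stronger inhibition and higher numbers for weaker inhibition), compound 1 gives 2 nM, the highest of the three numbers recorded. Its two measured neighbours each carry a methyl in place of hydrogen on an aromatic carbon: compound 2 `Cc1ccc(N2CCN(c3cc(C(F)(F)F)ccc3CNC(=O)C(C)c3ccc(NS(C)(=O)=O)c(F)c3)CC2)cc1` gives 0.7 nM and compound 3 `Cc1cccc(N2CCN(c3cc(C(F)(F)F)ccc3CNC(=O)C(C)c3ccc(NS(C)(=O)=O)c(F)c3)CC2)c1` gives 1.8 nM. The steps are a 2.9-fold lower number from compound 1 to compound 2 (0.46 log units; beyond the scatter) and a 1.1-fold lower number from compound 1 to compound 3 (0.05 log units; within the scatter), while a 2.6-fold higher number from compound 2 to compound 3 (0.41 log units; beyond the scatter).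

Compound 4 `CC(C(=O)NCc1ccc(C(F)(F)F)cc1SC1CCCC1)c1ccc(NS(C)(=O)=O)c(F)c1` departs from compound 1 in a different way: cyclopentylsulfanyl in place of 4-phenylpiperazin-1-yl on an aromatic carbon. The group that leaves is the one whose aromatic ring carried the methyl in compounds 2 and 3; the group that enters sits on an aromatic carbon of a six-membered aromatic ring of carbon only, ortho to a large group and meta to a trifluoromethyl group. Among the compounds with values here, none of the measured steps tests this exchange; they only show that a small addition on the leaving group moves the number by modest amounts, and they say nothing about removing that group altogether. With the whole group replaced by a smaller one, a larger step is expected, more likely toward a higher number in this assay, though the direction remains uncertain. Compound 4 is therefore expected to show a 5.0-fold higher number from compound 1 to compound 4 (0.70 log units; beyond the scatter). The estimate for compound 4 is 10 nM, within 2 nM to 60 nM.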

Compound 4, inhibition constant: 0.3 nM
Compound 4: the middle estimate sits 33-fold (1.52 log units) above what was measured, and the stated range ends above it.
By their numbers in this assay, from the lowest: compound 4; then compound 2; then compounds 3 and 1 (each within the scatter of the next).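

In this assay, replacing the entire 4-phenylpiperazin-1-yl group with cyclopentylsulfanyl gives a 6.7-fold lower number from compound 1 to compound 4 (0.82 log units; beyond the scatter), so the number at this position does not depend on keeping the leaving group's phenyl ring or its nitrogen-containing ring. The earlier compounds shown here tested only a methyl added to the phenyl ring, whereas this change shows that a group with fewer heavy atoms, attached through sulfur, can stand in for 4-phenylpiperazin-1-yl on the aromatic carbon that is ortho to a large group and meta to a trifluoromethyl group, and still lower the number. Nothing available explains why this exchange has that effect.

The compounds shown leave open whether the sulfur or the five-membered ring accounts for the step, and how a cyclopentyloxy group, with oxygen in place of sulfur, or a cyclohexylsulfanyl group would behave at this position. Also open, going by these compounds, is whether a methyl on the cyclopentyl ring would shift the number as the methyl on the phenyl ring did, with a 2.9-fold lower number from compound 1 to compound 2 (0.46 log units; beyond the scatter), in the piperazine series.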